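A Fluorine Added to the Least Stable Compound

The source may hold more compounds than are shown below. What is called first, only, known or untested is meant among the compounds shown, and "the series" means these compounds.

Measurements exist for a pair of compounds. In an ADME assay on microsomes from liver (Mus musculus) for metabolic stability, with a stated time of 30 min (a lower number here means that less of the compound is left, a higher number that more of the compound is left), compound 1 `CCn1c(=O)/c(=C2\Sc3ccc(F)cc3N2C)s/c1=C\c1ccccn1` gives 19%. Compound 2 `CCn1c(=O)/c(=C2\Sc3ccccc3N2C)s/c1=C\c1ccncc1` gives 6% in this assay, the lowest of the pair; compound 1 lies beyond the scatter above it. Compound 3 `CCn1c(=O)/c(=C2\Sc3ccc(F)cc3N2C)s/c1=C\c1ccncc1` is compound 2 with fluoro in place of hydrogen on an aromatic carbon. Among the measured compounds shown here, compound 1 also carries this fluoro but differs from compound 2 elsewhere, so no single step between measured compounds isolates the change. A small rise is expected, one that may not go beyond the scatter. Compound 3 is estimated at 10%, with a range from 3% to 25%, an expected step of a number 4 percentage points higher from compound 2 to compound 3 (within the scatter).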

Compound 3, percent of the compound remaining: 23%
Estimate against measurement, compound 3: 13 percentage points below; the range from low to high includes it.
By their numbers in this assay, from the lowest: compound 2; then compounds 1 and 3 (each within the scatter of the next).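

In this assay, fluoro in place of hydrogen on an aromatic carbon gives a number 17 percentage points higher from compound 2 to compound 3 (beyond the scatter), so this carbon of the shared core does respond to a single change when pyridin-4-yl is present. With fluoro in place, pyridin-4-yl instead of pyridin-2-yl gives a number 4 percentage points higher from compound 1 to compound 3 (within the scatter), so these two groups cannot be told apart here. Nothing measured explains the rise.

Open, on these data alone, is whether a chlorine atom or a methoxy group on this carbon would give a similar result. Also open, as far as these compounds go, is whether fluoro on another carbon of this ring would.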